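A Methyl Added to the Sulfonyl-Bearing Ring

The source may report more compounds than this note shows. Statements on the series, on what has been measured and on what is new or still open speak of the compounds shown alone.

Compound 1 `CC1CCN(c2c(S(=O)(=O)c3ccccc3)cnc3ccccc23)CC1` is the plainest of three measured analogues built on a shared core. In an assay on isolated protein for displacement of a labelled ligand from metabotropic glutamate receptor 5 (Homo sapiens), with a stated time of 60 min, tested at 1 uM (a higher number here means more inhibition at the concentration tested (going by the name of the read-out), a lower number less inhibition), compound 1 gives 89.2%. Compound 3 `CC1CCN(c2c(S(=O)(=O)c3ccccc3)cnc3ccc(Cl)cc23)CC1` gives 59%, and compound 2 `CC1CCN(c2c(S(=O)(=O)c3cc(Cl)cc(Cl)c3)cnc3ccc(F)cc23)CC1` gives 69%. Among these three numbers compound 3 has the lowest; its gap to compound 2 lies within the usual scatter, while its gap to compound 1 lies beyond it, as the single-place step a number 30.2 percentage points lower from compound 1 to compound 3 (beyond the scatter) shows.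

Compound 4 `Cc1ccc(S(=O)(=O)c2cnc3ccc(Cl)cc3c2N2CCC(C)CC2)cc1` differs from compound 3 in one place: methyl in place of hydrogen on an aromatic carbon.

Going by the values given here, no measured step alters the ring that carries the sulfonyl group in one place alone. Among the compounds with values here, compound 2 has two chloro groups on that ring, but it also carries a fluoro elsewhere, so its comparison with compound 3 shows only that the two values sit within the scatter of each other. Within the data shown here, the one clean step concerns a chloro on the core and says nothing about a methyl on this ring. The data therefore give no ground to expect a move beyond the scatter in either direction, and compound 4 is estimated at 58%, with a range from 35% to 80%, a step of a number 1 percentage points lower from compound 3 to compound 4 (within the scatter) that is expected to stay within the scatter.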

Compound 4, a percentage reported as inhibition, at one concentration (the size of the read-out at that concentration, not a potency): 95%
For compound 4 the middle estimate is 37 percentage points below the measured one; measured number above the stated range.
By their numbers in this assay, from the lowest: compounds 3 and 2 (each within the scatter of the next); then compounds 1 and 4 (each within the scatter of the next).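

Phenyl to 4-methylphenyl is a small change, adding 1 heavy atom para to a large group, yet in this assay it gives a number 36 percentage points higher from compound 3 to compound 4 (beyond the scatter). It is the first step shown that alters the ring carrying the sulfonyl group in one place alone, and it shows that this ring is far from indifferent to substitution, whereas the only earlier clean step, a chloro on the shared core, went the other way, with a number 30.2 percentage points lower from compound 1 to compound 3 (beyond the scatter). Nothing available explains why a single methyl at this position has so large an effect.

The compounds shown leave open whether the rise belongs to the methyl itself or would also appear with an ethyl, a methoxy or a carboxylic acid at the same place. Going by these compounds alone, they also leave open whether the methyl would act in the same way on the core of compound 1, which has no chloro, so the step so far holds for this one pair alone.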